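A Trifluoromethyl Enters the Oxazolidinone Ring

This account rests on a few compounds, and the source may have more. Where it says the series, first, only, none or still open, it means among the compounds named here.

Compound 3 `Nc1nc(-c2nn(Cc3ccccc3F)c3ncccc23)nc(N)c1N1CCOC1=O` is one of three close relatives that share a core and differ only in the group carried on one aromatic carbon. In an assay on cells for activation of Guanylate cyclase soluble subunit alpha-1 (Rattus norvegicus), read by cGMP accumulation and immunoassay, with a stated time of 10 min (a lower number here means that less compound is needed, a higher number that more compound is needed for the effect), compound 3 gives 0.3 uM. Compound 1 `CCN(C(=O)OC)c1c(N)nc(-c2nn(Cc3ccccc3F)c3ncccc23)nc1N` gives 0.2 uM and compound 2 `COC(=O)N(CCO)c1c(N)nc(-c2nn(Cc3ccccc3F)c3ncccc23)nc1N` gives 0.3 uM. The step of a 1.5-fold higher number from compound 1 to compound 3 (0.18 log units; within the scatter) and the step of no change at the digits printed from compound 2 to compound 3 (within the scatter) both lie within the scatter, so compound 3 stands level with compound 2, the two together the highest of the three numbers, and compound 1 sits within the scatter of both. The step of a 1.5-fold higher number from compound 1 to compound 2 (0.18 log units; within the scatter) likewise stays within the scatter.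

Compound 4 `Nc1nc(-c2nn(Cc3ccccc3F)c3ncccc23)nc(N)c1N1C[C@@H](C(F)(F)F)OC1=O` has not yet been measured. It differs from compound 3 in one place: trifluoromethyl in place of hydrogen on a saturated ring carbon. None of the three measured steps touches a saturated ring carbon of the five-membered ring; all three concern the group on the aromatic carbon, and each of them was within the scatter. For the measured compounds named here, the data therefore hold no measured step that bears directly on this change. On that basis compound 4 is expected to stay close to compound 3, with a step of no change at the digits printed from compound 3 to compound 4 (within the scatter) that is expected to remain within the scatter. The estimate for compound 4 in this assay is 0.3 uM, with a range from 0.1 uM to 1 uM.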

Compound 4, minimum effective concentration: 0.03 uM
Estimate against measurement, compound 4: 10-fold (1.00 log units) above; the whole stated range lies above it.
By their numbers in this assay, from the lowest: compound 4; then compounds 1, 2 and 3 (each within the scatter of the next).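

In this assay, for the compounds shown here, trifluoromethyl in place of hydrogen on a saturated ring carbon, next to the ring oxygen, gives a 10-fold lower number from compound 3 to compound 4 (1.00 log units; beyond the scatter) and is the first change in this set to move the number beyond the scatter, which shows that this ring position responds to substitution in a way the earlier changes on the aromatic carbon did not reveal. The 2-oxo-5-(trifluoromethyl)-1,3-oxazolidin-3-yl group also separates compound 4 from both open-chain relatives, with a 10-fold lower number from compound 2 to compound 4 (1.00 log units; beyond the scatter) and with a 6.7-fold lower number from compound 1 to compound 4 (0.82 log units; beyond the scatter) in the same direction, while compounds 1, 2 and 3 remained within the scatter of one another. Nothing supplied here gives a measured reason for this step.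

The compounds shown leave open whether a methyl, a difluoromethyl or a pentafluoroethyl group on the same ring carbon would give a step of similar size, and whether the opposite configuration at that carbon would behave alike. They also leave open whether a trifluoromethyl on the ethyl chain of compound 1 would produce a comparable change.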